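Sulfonamide series on a shared benzoxazole-free core: the sulfonyl aryl group

The compounds below may be only part of what the source reports. "The series", "measured", "known", "first", "only" and "open" are said of these compounds alone.

Measured so far:
Compound 1 `O=S(=O)(Nc1ccc2oc(-c3ccccc3)nc2c1)c1ccc(Cl)c(C(F)(F)F)c1`, in an assay on isolated protein for inhibition of malate dehydrogenase, mitochondrial (Sus scrofa), with stated times of 45 min and 30 min (a lower number here means a stronger inhibitor, a higher number a weaker inhibitor), compound 1 gives > 63000 nM.
Compound 2 `O=S(=O)(Nc1ccc2oc(-c3ccccc3)nc2c1)c1cccc(Cl)c1`, in this assay compound 2 gives > 63000 nM.
Compound 3 `O=S(=O)(Nc1ccc2oc(-c3ccccc3)nc2c1)c1cccs1`, in this assay compound 3 gives > 63000 nM.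

Each of these three values is a limit of this assay and not a number; all three sit at the limit of > 63000 nM in this assay, at which 3 of the 3 values shown sit. For compound 3 the reading is therefore only a limit. Within the data shown here, the one change among the measured compounds that bears on the sulfonyl substituent, a step that the two limits leave unreadable from compound 2 to compound 3, cannot be read because both of its ends are limits.

Compound 4 `O=S(=O)(Nc1ccc2oc(-c3ccccc3)nc2c1)c1ccc(Cl)c(Cl)c1` differs from compound 3 by 3,4-dichlorophenyl in place of thiophen-2-yl on a sulfonyl sulfur. Among the measured compounds shown here, no measured step gives a readable size for such a swap; compound 1 and compound 2, which each carry a chlorinated benzene ring on the sulfonyl sulfur, both stand at the same limit as compound 3. With nothing to point the other way, compound 4 is expected to stand at that limit too, so the estimated step that the limit leaves unreadable from compound 3 to compound 4 is none beyond the scatter. Compound 4 is thus estimated at 80000 nM in this assay, within a range from 30000 nM to 200000 nM.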

Compound 4, half-maximal inhibitory concentration: > 63000 nM
Compound 4 gave a limit, no number; the forecaster's own chance of this, stated with the estimate: 80%; the middle value does not contradict the limit.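

Compound 4 gives > 63000 nM in this assay, a limit and not a number. The steps to compound 4 from compound 1, compound 2 and compound 3 cannot be read, since all four compounds stand at one limit: the limit of > 63000 nM in this assay, at which 4 of the 4 values shown sit.

The compounds shown leave open whether any sulfonyl substituent on the shared core gives a measurable value in this assay.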